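The source may report more compounds than this note shows. Statements on the series, on what has been measured and on what is new or still open speak of the compounds shown alone.

In an ADME assay on HEK293 cells (Homo sapiens) for cytotoxicity, read by luminescence, with a stated time of 72 h (on this read-out higher numbers stand for an effect only at larger amounts of compound and lower numbers for an effect already at smaller amounts), three compounds sharing one core have been measured, and none has yet given a number. Compound 1 (`CCOC(=O)c1c(-c2cccc(Cl)c2)[nH]c2cc(OC)ccc2c1=O`) reads > 22000 nM, which is a limit of the assay. Compound 2 (`CCOC(=O)c1c(-c2cccc(Oc3ccccc3)c2)[nH]c2cc(OC)c(F)cc2c1=O`) reads > 22000 nM, which is also a limit. Compound 3 (`CCOC(=O)c1c(-c2cccc(F)c2)[nH]c2cc(OC)c(F)cc2c1=O`) reads > 22000 nM, again only a limit. The whole set therefore rests on one reading, (the limit of > 22000 nM in this assay, at which 3 of the 3 values shown sit).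

Compound 4 (`CCOC(=O)c1c(-c2cccc(Cl)c2)[nH]c2cc(OC)c(F)cc2c1=O`) follows from compound 3 by a single exchange, chloro in place of fluoro on an aromatic carbon, meta to a large group, turning 3-fluorophenyl into 3-chlorophenyl: chloro in place of fluoro on an aromatic carbon. For the measured compounds named here, the one measured step that bears on this is a step that the two limits leave unreadable from compound 2 to compound 3, and with a limit at both ends its size cannot be read. Compound 1, which already carries 3-chlorophenyl, shows the limit > 22000 nM. Neither observation points to a step in either direction. On this basis, the expected result is a number no higher from compound 3 to compound 4 (the limit leaves the size open), with no shift beyond the scatter. Compound 4 is estimated at 22000 nM, with an expected range from 12000 nM to 30000 nM. The most likely outcome is that this assay will again report only a limit.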

Compound 4, half-maximal effective concentration: > 22000 nM
Compound 4: only a limit was reported; the forecaster's own chance of this, stated with the estimate: 90%; the middle value sits exactly at the limit.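

In this assay compound 4 reads > 22000 nM and this is only a limit of the assay. Its steps from compound 1, compound 2 and compound 3 therefore cannot be read, and all four compounds share one reading: the limit of > 22000 nM in this assay, at which 4 of the 4 values shown sit.

The compounds shown leave open whether this assay would give an actual number for any of them, and so whether any exchange on the shared core changes the result.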